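A Methyl Added to the Strongest Compound So Far

The source may hold more compounds than are shown below. What is called first, only, known or untested is meant among the compounds shown, and "the series" means these compounds.

Measured so far in a functional assay on K562 cells (Homo sapiens) for inhibition, read by CCK-8 assay, with a stated time of 72 h; a lower number here means a stronger inhibitor, a higher number a weaker inhibitor:
- compound 1 `O=C(/C=C/c1cccnc1)NCCCCc1ccc(S(=O)(=O)Nc2ccccc2)cc1` gives 9.56 nM
- compound 2 `O=C(/C=C/c1cccnc1)NCCCCCc1ccc(S(=O)(=O)Nc2ccccc2)cc1` gives 146 nM
- compound 3 `O=C(/C=C/c1cccnc1)NCCCCCCc1cccc(S(=O)(=O)Nc2ccccc2)c1` gives 0.88 nM

Compound 3 has the lowest number of the three, which makes it the strongest inhibitor here, and its gaps to compound 1 and compound 2 both lie beyond the usual scatter.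

Compound 4 `Cc1cccc(NS(=O)(=O)c2cccc(CCCCCCNC(=O)/C=C/c3cccnc3)c2)c1` differs from compound 3 in one place, with methyl in place of hydrogen on an aromatic carbon, meta to a large group (methyl in place of hydrogen on an aromatic carbon). This turns phenylsulfamoyl into (3-methylphenyl)sulfamoyl. Within the data shown here, all three measured compounds carry the plain phenylsulfamoyl group, so no measured pair shows what this methyl does. The range must stay wide, since the values run from compound 3 at 0.88 nM to compound 2 at 146 nM in this small set. The expected result is a modest move towards a weaker number, an estimated 1.7-fold higher number from compound 3 to compound 4 (0.23 log units; within the scatter) that may not exceed the scatter. Compound 4 is expected at 1.5 nM, with an estimated range of 0.4 nM to 6 nM in this assay for now.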

Compound 4, half-maximal inhibitory concentration: 4.78 nM
Compound 4: middle estimate off by 3.2-fold (0.50 log units), on the low side; the range from low to high includes it.
By their numbers in this assay, from the lowest: compound 3; then compounds 4 and 1 (each within the scatter of the next); then compound 2.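

Among these compounds, the first measured pair that differ in one place shows that this ring carbon is sensitive to change: in this assay, turning phenylsulfamoyl into (3-methylphenyl)sulfamoyl gives a 5.4-fold higher number from compound 3 to compound 4 (0.73 log units; beyond the scatter). A single added carbon with no ring, charge or hydrogen-bond donor or acceptor is therefore enough to move the number beyond the usual scatter, yet compound 4 still gives 4.78 nM, so inhibition is reduced rather than lost. No measurement here bears on why the number rises.

The compounds shown leave open whether a fluorine, a chlorine, a methoxy group or an amine in place of this methyl would give a similar rise. They also leave open whether an ethyl group would raise the number further, and whether the same methyl would have the same effect on compound 1 or compound 2.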